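Propyl in place of fluoro in compound 1

The source may report more compounds than this note shows. Statements on the series, on what has been measured and on what is new or still open speak of the compounds shown alone.

Among the compounds with values here, compound 1 `Fc1cncc(OC[C@@H]2CCN2)c1` gives 0.076 nM in an assay on brain for binding affinity to Neuronal acetylcholine receptor; alpha4/beta2 (Rattus norvegicus), read by radioligand binding (on this read-out lower numbers stand for stronger inhibition and higher numbers for weaker inhibition), the higher of the two numbers measured so far. Within the data shown here, compound 2 `N#Cc1cncc(OC[C@@H]2CCN2)c1` gives 0.025 nM; the only measured step is a 3.0-fold lower number from compound 1 to compound 2 (0.48 log units; beyond the scatter). Compound 3 `CCCc1cncc(OC[C@@H]2CCN2)c1` carries the change (propyl in place of fluoro on an aromatic carbon). Among the measured compounds shown here, no measured step exchanges fluoro for propyl, so the cyano step bears only loosely on it, showing that this position tolerates substitution; a modest step in this assay toward a higher number is expected. Compound 3 is expected at 0.3 nM, between 0.05 nM and 2 nM. That estimate means an expected 3.9-fold higher number from compound 1 to compound 3 (0.60 log units; beyond the scatter).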

Compound 3, inhibition constant: 0.039 nM
For compound 3 the middle estimate is 7.7-fold (0.89 log units) above the measured one, and the stated range ends above it.
By their numbers in this assay, from the lowest: compounds 2, 3 and 1 (each within the scatter of the next, the first and the last beyond it).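

In this assay propyl in place of fluoro gives a 1.9-fold lower number from compound 1 to compound 3 (0.29 log units; within the scatter) and propyl in place of cyano gives a 1.6-fold higher number from compound 2 to compound 3 (0.19 log units; within the scatter) on the same aromatic carbon. This position therefore accepts an alkyl chain as well as fluoro or cyano, with neither step to propyl lying beyond the scatter. No supporting data bear on this tolerance.

On these data alone, how far it extends remains open: a longer chain such as hexyl, or a branched one such as tert-butyl, could stand differently here. As far as these compounds go, an amine or a carboxylic acid at this carbon is equally open.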